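Dichlorophenyl for methylphenyl on the pyrazole-type nitrogen

The source may report more compounds than this note shows. Statements on the series, on what has been measured and on what is new or still open speak of the compounds shown alone.

Measured so far:
compound 1 `Cc1ccccc1-n1cc(-c2ccccc2)c(-c2ccc3c(c2)NC(=O)CO3)n1` — 85.3%
compound 2 `O=C1COc2ccc(-c3[nH]c(-c4c[nH]c5ncccc45)nc3-c3ccccc3)cc2N1` — 86.8%

In a functional assay on A549 cells (Homo sapiens) for cytotoxicity, read by colorimetric assay and MTT assay, with a stated time of 3 days, tested at 20 uM (on this read-out lower numbers stand for a stronger effect and higher numbers for a weaker effect at the one concentration tested), compound 1 gives 85.3%. In this assay compound 2 gives 86.8%. The two numbers lie within the usual scatter of each other, so neither compound is set apart, and both sit at the weak end of the read-out at the single concentration tested. Going by the values given here, no pair of measured compounds differs in one place only, so no measured step is available to guide the next one.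

Compound 3 `O=C1COc2ccc(-c3nn(-c4cc(Cl)cc(Cl)c4)cc3-c3ccccc3)cc2N1` is the unmeasured case. Against compound 1 the change is 3,5-dichlorophenyl in place of 2-methylphenyl on an aromatic nitrogen. The shared core and the phenyl group are untouched.

Among the compounds with values here, with only two measured numbers, both weak and within scatter of each other, there is no basis for a large move. The step from compound 1 to compound 3 is expected to be a number 5.3 percentage points lower from compound 1 to compound 3 (within the scatter), a small shift that may well stay inside the scatter. For compound 3 the expected value in this assay is 80%, with a range from 62% to 95%.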

Compound 3, a percentage reported as activity, at one concentration (the size of the read-out at that concentration, not a potency): 70.2%
Compound 3: middle estimate off by 9.8 percentage points, on the high side; the measured number falls inside the stated range.
By their numbers in this assay, from the lowest: compound 3; then compounds 1 and 2 (each within the scatter of the next).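

In this assay, 3,5-dichlorophenyl in place of 2-methylphenyl on the aromatic nitrogen gives a number 15.1 percentage points lower from compound 1 to compound 3 (beyond the scatter), a modest step and the first in this series that can be read. Going by these compounds alone, with the shared core and the phenyl group unchanged, the step shows that the read-out responds to the group on this nitrogen, which the two earlier numbers, lying within the scatter of each other and joined by no step, could not show; the effect remains partial at the one concentration tested, with compound 3 at 70.2%. No measured data on the compounds bear on what lies behind this shift.

The step removes a methyl and brings in two chlorines in a single change, so the compounds shown do not separate the loss of the methyl from the entry of the chlorines. Also open, going by these compounds, is how far the read-out would move with an unsubstituted phenyl, or with a phenyl carrying a single chlorine, an amine or a carboxylic acid, on the same nitrogen.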